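From Furan-2-yl to 4-Methylphenyl: An Expected Cytotoxicity Value

The compounds below may be only part of what the source reports. "The series", "measured", "known", "first", "only" and "open" are said of these compounds alone.

Of the compounds shown here, three have so far been measured in a functional assay on K562 cells (Homo sapiens) for cytotoxicity, in the presence of a further agent that is not named here; on this read-out higher numbers stand for weaker inhibition and lower numbers for stronger inhibition. Compound 1 `Clc1ccc(-c2cc(-c3ccsc3)nc(-c3ccco3)c2)o1` gives 22400 nM, compound 2 `Clc1ccc(-c2cc(-c3ccco3)nc(-c3cccs3)c2)o1` gives 16000 nM, and compound 3 `Cc1ccccc1-c1cc(-c2ccc(Cl)o2)cc(-c2ccsc2)n1` gives 18400 nM. Compound 2 has the lowest of the three numbers, but compound 3 lies within the scatter of it, and the step of a 1.4-fold lower number from compound 1 to compound 2 (0.15 log units; within the scatter) is also within the scatter, so no order among the three can be read from these numbers.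

Compound 4 `Cc1ccc(-c2cc(-c3ccc(Cl)o3)cc(-c3cccs3)n2)cc1` differs from compound 2 in one place: 4-methylphenyl in place of furan-2-yl on an aromatic carbon. For the measured compounds named here, the measured step that bears on this is the one from compound 1 to compound 3, where 2-methylphenyl replaced furan-2-yl and gave a 1.2-fold lower number from compound 1 to compound 3 (0.09 log units; within the scatter). Here a 4-methylphenyl enters instead, on a core that carries thiophen-2-yl rather than thiophen-3-yl, yet the closest precedent points to no step beyond the scatter. Compound 4 is therefore expected to give 15000 nM, within a range from 6000 nM to 40000 nM. This corresponds to an expected step of a 1.1-fold lower number from compound 2 to compound 4 (0.03 log units; within the scatter).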

Compound 4, half-maximal inhibitory concentration: 21500 nM
Compound 4: the middle estimate sits 1.4-fold (0.16 log units) below what was measured; low and high end bracket the measured number.
By their numbers in this assay, from the lowest: compounds 2, 3, 4 and 1 (each within the scatter of the next).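

In this assay, putting 4-methylphenyl in place of furan-2-yl next to the ring nitrogen gives a 1.3-fold higher number from compound 2 to compound 4 (0.13 log units; within the scatter), so a hydrogen-bond acceptor leaves this position without the number moving beyond the scatter. The earlier compounds showed this only for 2-methylphenyl on the core carrying thiophen-3-yl, and the same now holds for 4-methylphenyl on the core carrying thiophen-2-yl, so neither replacement of furan-2-yl shown here separates from its parent. Nothing available explains why this position tolerates the exchange.

Every group shown at this position is a single aromatic ring, so it remains open whether an amine, a carboxylic acid or a longer alkyl chain there would shift the number beyond the scatter. On these data alone, it is also open whether 2-methylphenyl and 4-methylphenyl would differ on one and the same core.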